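Replacing the ethyl group of compound 3: working notes

This account rests on a few compounds, and the source may have more. Where it says the series, first, only, none or still open, it means among the compounds named here.

In a functional assay on HepG2 cells (Homo sapiens) for inhibition, read by scintillation counting, with a stated time of 2 h (a lower number here means a stronger inhibitor, a higher number a weaker inhibitor), compound 1 (`CCNC(=O)Nc1sc2ccccc2c1C(=O)N1CCN(C2CCN(C(=O)CC)CC2)CC1`) stands at "not determined" (no result reported) and so offers no number. Compound 2 (`CCNC(=O)Nc1sc2ccccc2c1C(=O)N1CCN(C2CCN(C(=O)C3CCCCC3)CC2)CC1`) gives 146 nM and compound 3 (`CCNC(=O)Nc1sc2ccccc2c1C(=O)N1CCN(C2CCN(C(=O)OCC)CC2)CC1`) gives 228 nM in the same read-out. Within the data shown here, the one measured step runs a 1.6-fold higher number from compound 2 to compound 3 (0.19 log units; within the scatter) with ethoxy in place of cyclohexyl on a carbonyl carbon, and it stays within the scatter. Among the measured compounds shown here, compound 3 therefore stands level with the only other number. Compound 4 (`CCNC(=O)Nc1sc2ccccc2c1C(=O)N1CCN(C2CCN(C(=O)OC(C)(C)C(F)(F)F)CC2)CC1`) differs by 1-methyl-1-(trifluoromethyl)ethyl in place of ethyl on an oxygen next to a carbonyl group with 1-methyl-1-(trifluoromethyl)ethyl in place of ethyl on an oxygen next to a carbonyl group. For the measured compounds named here, no measured step varies that group, so the one step is a loose guide and no shift beyond the scatter is expected. The expected change is a 1.3-fold lower number from compound 3 to compound 4 (0.13 log units; within the scatter) as estimated here. Compound 4 is estimated in this assay at 170 nM within an expected range from 60 nM to 480 nM overall.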

Compound 4, half-maximal inhibitory concentration: 81 nM
Beside the measured number, compound 4's estimate is 2.1-fold (0.32 log units) above it; the measured number falls inside the stated range.
By their numbers in this assay, from the lowest: compounds 4, 2 and 3 (each within the scatter of the next, the first and the last beyond it).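

Among these compounds, on the oxygen next to a carbonyl group, 1-methyl-1-(trifluoromethyl)ethyl in place of ethyl gives a 2.8-fold lower number from compound 3 to compound 4 (0.45 log units; beyond the scatter) in this assay and is the first step beyond the scatter, so the group at this position can move the number. Set against cyclohexyl on a carbonyl carbon, 1-methyl-1-(trifluoromethyl)ethoxy gives a 1.8-fold lower number from compound 2 to compound 4 (0.26 log units; within the scatter) and so supports no order between those two compounds. No supporting data bear on why the number moved.

The compounds shown do not separate the two added methyl groups from the trifluoromethyl group. A tert-butyl or 2,2,2-trifluoroethyl group on the same oxygen would begin to pull those parts apart.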